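Swapping a triazole aryl group in two sulfonamide pairs

A few compounds are considered here, and "the series" means these few. Any claim that something is new, unique, unknown or untested is made for them only; others in the source may bear on it.

Compound 1 `Cc1ccc(-n2cc(-c3ccccc3NS(=O)(=O)c3c[nH]c(=O)[nH]c3=O)nn2)cc1` and compound 2 `O=c1[nH]cc(S(=O)(=O)Nc2ccccc2-c2cn(-c3ccccc3F)nn2)c(=O)[nH]1` share one core; how that core differs from the core of compound 3 `Cc1ccc(-n2cc(-c3cccc(NS(=O)(=O)c4c[nH]c(=O)[nH]c4=O)c3)nn2)cc1` is not broken down here. In an ADME assay on L02 cells (Homo sapiens) for cytotoxicity, read by MTT assay, with a stated time of 24 h (a lower number here means that less compound is tolerated, a higher number that more compound is tolerated), compound 1 gives only a limit, > 100000 nM. Compound 2 likewise gives only a limit in this assay, > 100000 nM. The change between them, (2-fluorophenyl in place of 4-methylphenyl on an aromatic nitrogen), thus yields a step that the two limits leave unreadable from compound 1 to compound 2, unreadable because of the limit of > 100000 nM in this assay, at which 2 of the 3 values shown sit. Compound 3 gives 23100 nM in this assay. Compound 4 `O=c1[nH]cc(S(=O)(=O)Nc2cccc(-c3cn(-c4ccccc4F)nn3)c2)c(=O)[nH]1` carries the same change, (2-fluorophenyl in place of 4-methylphenyl on an aromatic nitrogen). Given the unreadable a step that the two limits leave unreadable from compound 1 to compound 2, compound 4 is expected to show an estimated step of a 1.1-fold higher number from compound 3 to compound 4 (0.03 log units; within the scatter). Compound 4 is therefore estimated at 25000 nM, expected to lie between 9000 nM and 90000 nM.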

Compound 4, half-maximal cytotoxic concentration: "not toxic" (no number reported)
Nothing numeric was reported for compound 4, and the estimate cannot be compared.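

For the compounds shown here, compound 4 was reported only as "not toxic", so no step from compound 3 to compound 4 can be read in this assay. What 2-fluorophenyl in place of 4-methylphenyl does to tolerance stays open in both pairs: the limit of > 100000 nM in this assay, at which 2 of the 4 values shown sit.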